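Replacing 3-(trifluoromethyl)phenyl with methyl in compound 4

This account rests on a few compounds, and the source may have more. Where it says the series, first, only, none or still open, it means among the compounds named here.

Three compounds measured in an ADME assay on microsomes from liver (Homo sapiens) for metabolic stability, read by LC-MS, with a stated time of 10 min (on this read-out lower numbers stand for a less stable compound and higher numbers for a more stable compound), so far
- compound 1 `CN(C[C@H]1Cc2c(cccc2N2CCN(C3COC3)CC2)CN1)[C@H]1CCCc2cccnc21` gives 83.1%
- compound 2 `C[C@@H]1CN(c2cccc3c2C[C@H](CN(C)[C@H]2CCCc4cccnc42)NC3)C[C@H](C)N1` gives 100%
- compound 3 `CN(C[C@H]1Cc2c(cccc2N2CCN(c3cccc(C(F)(F)F)c3)CC2)CN1)[C@H]1CCCc2cccnc21` gives 90.3%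

The value of compound 3 lies within the usual scatter of both other values, although compound 1 and compound 2 are further apart than that scatter. Compound 4 `CN1CCN(c2cccc3c2C[C@H](CN(C)[C@H]2CCCc4cccnc42)NC3)CC1` differs from compound 3 in one place: methyl in place of 3-(trifluoromethyl)phenyl on an amine nitrogen in a ring.

The closest evidence is a change on that same nitrogen, where 3-(trifluoromethyl)phenyl in place of oxetan-3-yl gave a number 7.2 percentage points higher from compound 1 to compound 3 (within the scatter) and so no clear shift. A wider change, 3,5-dimethylpiperazin-1-yl in place of 4-(oxetan-3-yl)piperazin-1-yl on an aromatic carbon, gave a number 16.9 percentage points higher from compound 1 to compound 2 (beyond the scatter) and so a modest rise. Within the data shown here, no measured compound carries methyl at this place, so the expectation is uncertain. The estimated step is a number 2.3 percentage points lower from compound 3 to compound 4 (within the scatter), which is expected to stay within the usual scatter of this assay. For compound 4 the expected value is 88%, with an estimated range from 74% to 100%.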

Compound 4, percent of the compound remaining: 75.8%
For compound 4 the middle estimate is 12.2 percentage points above the measured one; the measured number falls inside the stated range.
By their numbers in this assay, from the lowest: compounds 4, 1, 3 and 2 (each within the scatter of the next, the first and the last beyond it).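

In this assay, the group on this amine nitrogen can now be seen to shift the number: methyl in place of 3-(trifluoromethyl)phenyl gives a number 14.5 percentage points lower from compound 3 to compound 4 (beyond the scatter), while methyl in place of oxetan-3-yl on the same nitrogen gives only a number 7.3 percentage points lower from compound 1 to compound 4 (within the scatter). The change from 3,5-dimethylpiperazin-1-yl to 4-methylpiperazin-1-yl on the aromatic carbon also reaches past the usual scatter, with a number 24.2 percentage points lower from compound 2 to compound 4 (beyond the scatter). Nothing measured here explains these steps.

The compounds shown leave open whether the step from compound 3 belongs to the aromatic ring or to the trifluoromethyl on it, and a plain phenyl on that nitrogen would separate the two. An ethyl or a cyclopropyl there would show how the number behaves for small groups other than methyl.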